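The compounds below may be only part of what the source reports. "The series", "measured", "known", "first", "only" and "open" are said of these compounds alone.

Measured compounds, read in a functional assay on DU-145 cells (Homo sapiens) for cytotoxicity, read by CCK-8 assay and cell counting, with a stated time of 72 h; on this read-out higher numbers stand for weaker inhibition and lower numbers for stronger inhibition:

- compound 1 `COc1ccc(-c2cc3cc(C)ccc3c(-c3cccc(O)c3)n2)cc1OC`: 6510 nM
- compound 2 `COc1cccc(-c2nc(-c3ccc(OC)c(OC)c3)cc3cc(C)ccc23)c1`: a limit of the assay, not a number, > 50000 nM
- compound 3 `COc1ccc(-c2cc3cc(C)ccc3c(-c3ccc(O)cc3)n2)cc1OC`: 5980 nM

Compound 3 holds the lowest of the two numbers available; its nearest neighbour is compound 1, and the step of a 1.1-fold lower number from compound 1 to compound 3 (0.04 log units; within the scatter) lies within the scatter, so the two are not ordered by these data. The change from the 3-hydroxyphenyl of compound 1 to the 4-hydroxyphenyl of compound 3 therefore moves nothing that can be trusted.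

Compound 4 `COc1ccc(-c2nc(-c3ccc(OC)c(OC)c3)cc3cc(C)ccc23)cc1` differs from compound 3 by methyl in place of hydrogen on an oxygen on an aromatic ring. Within the data shown here, the one measured step of the same kind is an at least 7.6-fold higher number from compound 1 to compound 2 (0.88 log units; beyond the scatter), where compound 2 reaches only (the limit of > 50000 nM in this assay, at which 1 of the 3 values shown sits). The step of an at least 8.3-fold lower number from compound 2 to compound 3 (0.92 log units; beyond the scatter) combines the reverse of that methylation with the positional shift and is of similar size. On this basis a rise beyond the scatter is expected, a 7.5-fold higher number from compound 3 to compound 4 (0.88 log units; beyond the scatter), and compound 4 is estimated at 45000 nM, with a range of 18000 nM to 120000 nM, and a fair chance that only a limit is returned.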

Compound 4, half-maximal inhibitory concentration: > 50000 nM
Compound 4 was reported as a limit; the forecaster's own chance of this, stated with the estimate: 45%; middle value at least 1.1-fold (0.04 log units) away from the limit.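

The same methylation now costs activity from the 4-hydroxyphenyl as well as from the 3-hydroxyphenyl in this assay, with an at least 8.3-fold higher number from compound 3 to compound 4 (0.92 log units; beyond the scatter), so the loss is not confined to one placement of the hydroxy group. Replacing the 3-hydroxyphenyl with 4-methoxyphenyl gives an at least 7.6-fold higher number from compound 1 to compound 4 (0.88 log units; beyond the scatter), while the step between the two methoxy compounds, compound 2 and compound 4, cannot be read, since both values are limits. The two methylation steps can only be set side by side with caution: the same change on two cores in this assay, an at least 7.6-fold higher number (0.88 log units; beyond the scatter) from compound 1 to compound 2 and an at least 8.3-fold higher number (0.92 log units; beyond the scatter) from compound 3 to compound 4; the limit leaves it open whether they differ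

Going by these compounds, how far the two methoxy compounds differ from each other stays open: the limit of > 50000 nM in this assay, at which 2 of the 4 values shown sit. Also open is whether an ethoxy group, an aminoethoxy chain or a carboxylic acid on that ring would stay near compound 3 or follow methoxy to the limit.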